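A few compounds are considered here, and "the series" means these few. Any claim that something is new, unique, unknown or untested is made for them only; others in the source may bear on it.

Compound 1 `O=C1CC[C@@H](C(=O)N2CCC(NS(=O)(=O)c3cc(S(=O)(=O)c4ccccc4)ccc3C(F)(F)F)CC2)N1` is measured in an assay on isolated protein for binding affinity to secreted frizzled-related protein 1 (Homo sapiens), read by fluorescence (on this read-out higher numbers stand for weaker inhibition and lower numbers for stronger inhibition), at 90 nM. In this assay compound 2 `CN(C)CC(=O)N1CCC[C@H]1C(=O)N1CCC(NS(=O)(=O)c2cc(S(=O)(=O)c3ccccc3)ccc2C(F)(F)F)CC1` gives 90 nM, and compound 3 `CN(C)c1ccc(C(=O)N2CCC[C@H]2C(=O)N2CCC(NS(=O)(=O)c3cc(S(=O)(=O)c4ccccc4)ccc3C(F)(F)F)CC2)cc1` gives 110 nM. Compound 1 stands level with compound 2 at the digits printed, the two together the lowest of the three numbers; compound 2 is its nearest neighbour, compound 3 its furthest, and the whole spread is within the scatter.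

Compound 4 `CN(C)C(=O)N1CCC[C@H]1C(=O)N1CCC(NS(=O)(=O)c2cc(S(=O)(=O)c3ccccc3)ccc2C(F)(F)F)CC1` carries the change (1-(dimethylcarbamoyl)pyrrolidin-2-yl in place of 5-oxopyrrolidin-2-yl on a carbonyl carbon). Among the compounds with values here, two measured steps bear on it, both altering the same portion of the molecule on the same carbonyl carbon: no change at the digits printed from compound 1 to compound 2 (within the scatter) and a 1.2-fold higher number from compound 2 to compound 3 (0.09 log units; within the scatter). Neither moved the number beyond the scatter, and the rest of the core is untouched. For compound 4 the expected step is therefore a 1.1-fold higher number from compound 1 to compound 4 (0.02 log units; within the scatter), no change beyond the scatter in either direction. Compound 4 is estimated at 95 nM, with a range from 45 nM to 200 nM.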

Compound 4, half-maximal inhibitory concentration: 30 nM
The estimate for compound 4 lay 3.2-fold (0.50 log units) above the measured number; the measured number lies below the stated range.
By their numbers in this assay, from the lowest: compound 4; then compounds 1, 2 and 3 (each within the scatter of the next).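

Compounds 1, 2 and 3 lie within the scatter of one another, yet this position can still move the number in this assay: 1-(dimethylcarbamoyl)pyrrolidin-2-yl in place of 5-oxopyrrolidin-2-yl gives a 3.0-fold lower number from compound 1 to compound 4 (0.48 log units; beyond the scatter). The group on the carbonyl carbon of the acylated pyrrolidine also matters, since dimethylamino gives a 3.0-fold lower number from compound 2 to compound 4 (0.48 log units; beyond the scatter) in place of (dimethylamino)methyl and a 3.7-fold lower number from compound 3 to compound 4 (0.56 log units; beyond the scatter) in place of 4-(dimethylamino)phenyl. Among these compounds, the lower number goes only with dimethylamino on that carbonyl carbon, and compounds 2 and 3 show that a dimethylamino group elsewhere in the acyl group does not bring it. Nothing measured here explains this difference.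

On these data alone, whether methylamino, pyrrolidin-1-yl, morpholin-4-yl or methoxy on that carbonyl carbon would keep the lower number remains open. As far as these compounds go, the effect of the opposite configuration at the stereocentre also remains open.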